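Thiophen-2-yl in Place of Furan-2-yl: An Expected Step

The source may report more compounds than this note shows. Statements on the series, on what has been measured and on what is new or still open speak of the compounds shown alone.

The measured compounds and their values in an assay on membranes from CHO cells for displacement of a labelled ligand from adenosine receptor A1 (Homo sapiens), read by scintillation counting, with a stated time of 60 min, tested at 1 uM; on this read-out higher numbers stand for more inhibition at the one concentration tested (going by the name of the read-out) and lower numbers for less inhibition:
compound 1 `CC1=C(C(=O)OCc2ccccc2)C(c2cccs2)NC(=O)N1` gives 45%.
compound 2 `CCNC(=O)C1=C(C)NC(=O)NC1c1cccs1` gives 1%.
compound 3 `CC1=C(C(=O)OC2CCCC2)C(c2ccco2)NC(=O)N1` gives 1%.

Compound 3 stands level with compound 2 at the digits shown, the two together being the lowest of the three numbers and within the scatter of each other. Compound 1 lies well above both, beyond the scatter.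

The step considered leads to compound 4 `CC1=C(C(=O)OC2CCCC2)C(c2cccs2)NC(=O)N1`. The change is thiophen-2-yl in place of furan-2-yl on a saturated ring carbon. Among the measured compounds shown here, no measured pair in this set isolates that change, so the expectation rests on what the three values show. For the measured compounds named here, compound 1, the only compound with a clearly raised reading, carries thiophen-2-yl, but compound 2 carries the same ring and gives a low value in this assay, so the ring alone does not settle the matter. A rise of modest size is expected, from compound 3 to compound 4, as a number 14 percentage points higher from compound 3 to compound 4 (beyond the scatter). Compound 4 is therefore estimated at 15%, within a range from 0% to 40%.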

Compound 4, a percentage reported as inhibition, at one concentration (the size of the read-out at that concentration, not a potency): 9%
The estimate for compound 4 lay 6 percentage points above the measured number; low and high end bracket the measured number.
By their numbers in this assay, from the lowest: compounds 2, 3 and 4 (each within the scatter of the next); then compound 1.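

In this assay, thiophen-2-yl in place of furan-2-yl on the saturated ring carbon gives a number 8 percentage points higher from compound 3 to compound 4 (within the scatter) so, with cyclopentyl on the ester oxygen, exchanging these two rings leaves the reading within the usual variation between repeats. Cyclopentyloxy in place of ethylamino on the carbonyl carbon, with thiophen-2-yl kept, gives a number 8 percentage points higher from compound 2 to compound 4 (within the scatter) while cyclopentyl in place of benzyl on the oxygen gives a number 36 percentage points lower from compound 1 to compound 4 (beyond the scatter) and so, among these single changes, only the one involving benzyl clearly shifts the reading. Nothing available explains why these steps differ in size.

Still open, on these data alone, is whether thiophen-2-yl and furan-2-yl would also read alike with benzyl on the ester oxygen. Also open, as far as these compounds go, is how a pyridine ring on the same ring carbon would read, or a longer chain such as hexyl on that oxygen.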